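Stereochemical definition of the piperidine amide in compound 1

The source may hold more compounds than are shown below. What is called first, only, known or untested is meant among the compounds shown, and "the series" means these compounds.

Measured so far:
compound 1, `Cn1ncc(Cl)c1-c1cc(C(=O)NC2CNCCC2c2ccc(C(F)(F)F)cc2)oc1Cl`: 7.2 nM
compound 2, `Cn1ncc(Cl)c1-c1cc(C(=O)N[C@@H]2CN[C@H](CC(O)CO)C[C@H]2c2ccc(Cl)c(Cl)c2)oc1Cl`: 3.79 nM

In an assay for inhibition of RAC-alpha serine/threonine-protein kinase (Homo sapiens), read by HTRF, with a stated time of 1 h (a higher number here means a weaker inhibitor, a lower number a stronger inhibitor), compound 1 gives 7.2 nM, the higher of the two numbers. Its nearest neighbour is compound 2, which gives 3.79 nM; the gap between compound 1 and compound 2 is within the scatter, so the two stand level.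

Compound 3, `Cn1ncc(Cl)c1-c1cc(C(=O)N[C@@H]2CNCC[C@H]2c2ccc(C(F)(F)F)cc2)oc1Cl`, is compound 1 with its stereochemistry written out: the two compounds have the same atoms and bonds; at least one stereo element is drawn with a configuration in one of them and without one in the other: 2 of 2 stereo elements differ; a stereocentre at a saturated ring carbon is drawn without a configuration in compound 1 and S in compound 3; a stereocentre at a saturated ring carbon is drawn without a configuration in compound 1 and S in compound 3. For the measured compounds named here, no step between measured compounds matches this change. A compound drawn without configuration covers more than one stereoisomer, and a single defined isomer is expected to give a number equal to or lower than the undefined parent, so a modest downward step is expected for a 2.1-fold lower number from compound 1 to compound 3 (0.31 log units; beyond the scatter), close to the edge of the scatter. Compound 3 is therefore expected to give about 3.5 nM in this assay, within 1.2 nM to 10 nM.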

Compound 3, half-maximal inhibitory concentration: 9.3 nM
Beside the measured number, compound 3's estimate is 2.7-fold (0.42 log units) below it, within the range that was stated.
By their numbers in this assay, from the lowest: compounds 2, 1 and 3 (each within the scatter of the next, the first and the last beyond it).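

In this assay, drawing both saturated ring stereocentres as S gives a 1.3-fold higher number from compound 1 to compound 3 (0.11 log units; within the scatter), so the two compounds stand level. For the compounds shown here, at this position, the defined S,S form therefore reads the same as the undefined drawing within the scatter, a comparison that the earlier compounds could not offer. This is the first direct reading of configuration in the series, and it rests on a comparison of drawn stereochemistry alone: the fact that one of compounds 1 and 3 is drawn with a defined configuration and the other without, at the place where they differ

Still open, on these data alone, is how forms with R at one or both of these stereocentres read in this assay, and thus whether configuration at this position affects the number at all. Also open, as far as these compounds go, is whether the S,S form keeps its level when a nitrile stands in place of the trifluoromethyl group or a primary amine is carried on the piperidine amide.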